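A Methoxy Group Enters on the Core of Compound 1

This account rests on a few compounds, and the source may have more. Where it says the series, first, only, none or still open, it means among the compounds named here.

Compound 1 `c1ccc(-c2nc3sc(-c4ccccc4)cn3n2)cc1`: 37%
Compound 2 `CC(=O)c1ccc(NC(=O)Cn2nc(-c3ccc(Cl)cc3)nc2N)cc1`: 20.3%
Compound 3 `C/C(=N/O)c1ccc(NC(=O)Cn2nc(C(F)(F)F)nc2N)cc1`: 20.3%

Of the compounds shown here, three have been measured in a functional assay on PC-3 cells (Homo sapiens) for inhibition, read by sulforhodamine B assay, with a stated time of 48 h, tested at 10 uM; on this read-out higher numbers stand for more inhibition of growth at the one concentration tested and lower numbers for less inhibition of growth. Compound 1 stands highest of the three numbers. Compound 2 lies lower by a difference that is beyond the scatter, and compound 3 lies lower by the same difference, also beyond the scatter. Compound 2 and compound 3 share a different core from compound 1 and give the same number, so they say nothing about how the core of compound 1 tolerates a change.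

The unmeasured compound 4 `COc1ccc(-c2nc3sc(-c4ccccc4)cn3n2)cc1` keeps the core of compound 1 and differs from it in one place: methoxy in place of hydrogen on an aromatic carbon. Within the data shown here, no step between two measured compounds touches this position, so there is nothing to calibrate it against. A change of this kind is expected to move the number little, and the estimated step of a number 1 percentage points lower from compound 1 to compound 4 (within the scatter) is expected to stay within the scatter. Compound 4 is therefore estimated at 36% in this assay, within a range from 15% to 60%.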

Compound 4, percent growth inhibition at one concentration: 33%
Beside the measured number, compound 4's estimate is 3 percentage points above it; the range from low to high includes it.
By their numbers in this assay, from the lowest: compounds 2 and 3 (each within the scatter of the next); then compounds 4 and 1 (each within the scatter of the next).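

In this assay methoxy in place of hydrogen on an aromatic carbon, para to a large group, comes with a number 4 percentage points lower from compound 1 to compound 4 (within the scatter) and so the two compounds cannot be told apart at the one concentration tested. Among these compounds, this is the first step read on the core of compound 1, and it shows that this position can carry methoxy without a difference beyond the scatter, which compounds 2 and 3, with their different core, could not show. Nothing available explains this result.

As far as these compounds go, it remains open whether an amine, a carboxylic acid or a longer chain at this position would also stay within the scatter of compound 1. From the compounds shown here alone, it also remains open whether methoxy elsewhere on the core of compound 1 would give a similar number.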